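Working notes: from compound 2 to compound 3

The source may report more compounds than this note shows. Statements on the series, on what has been measured and on what is new or still open speak of the compounds shown alone.

- compound 1 `COc1cc(C(=O)O)ccc1OCCCCOc1ccc(C(=O)CC(C)C)c(O)c1C` gives 2190 ng.h/mL
- compound 2 `Cc1c(OCCCCOc2ccc(C(=O)O)cc2)ccc(C(=O)CC(C)C)c1O` gives 1550 ng.h/mL

Both values come from an ADME assay on the whole organism (plasma) for pharmacokinetics, with Rattus norvegicus as the target, at a dose of 2 mg/kg by the intravenous route; on this read-out lower numbers stand for lower exposure and higher numbers for higher exposure at the dose given. Among the measured compounds shown here, compound 2 stands within the scatter of compound 1, the only other measured compound. Compound 3 `Cc1c(OCCCCOc2ccc(F)c(C(=O)O)c2)ccc(C(=O)CC(C)C)c1O` differs from compound 2 by one change: 3-carboxy-4-fluorophenyl in place of 4-carboxyphenyl on an oxygen on a saturated carbon. For the measured compounds named here, the single measured step, a 1.4-fold lower number from compound 1 to compound 2 (0.15 log units; within the scatter), is also an exchange on the ring that holds the acid, though with a different group. Going by the values given here, no measured step covers this exact change, so no step beyond the scatter is expected in this assay. The expected step is a 1.0-fold lower number from compound 2 to compound 3 (0.01 log units; within the scatter). For compound 3 the estimated value is 1500 ng.h/mL, with an expected range of 700 ng.h/mL to 3200 ng.h/mL.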

Compound 3, area under the concentration-time curve: 863 ng.h/mL
Estimate against measurement, compound 3: 1.7-fold (0.24 log units) above; low and high end bracket the measured number.
By their numbers in this assay, from the lowest: compounds 3, 2 and 1 (each within the scatter of the next, the first and the last beyond it).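

In this assay, 3-carboxy-4-fluorophenyl in place of 4-carboxyphenyl on the oxygen gives a 1.8-fold lower number from compound 2 to compound 3 (0.25 log units; within the scatter), so this second exchange on the ring that holds the acid also stays inside the usual scatter. The change brings in a fluorine and a new place for the acid at once, and the two cannot be told apart here. No available evidence bears on this step. On these data alone, what remains open is how a chlorine in place of the fluorine, or an amide in place of the carboxylic acid, would read in this assay.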